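Swapping a phenyl for a methyl-isoxazole on a dithiocarbamate

The compounds below may be only part of what the source reports. "The series", "measured", "known", "first", "only" and "open" are said of these compounds alone.

Measured compounds:
compound 1, `NC(=O)CCSC(=S)NCc1cccnc1` — 1160 nM
compound 2, `S=C(NCc1cccnc1)SCCc1nc2ccccc2[nH]1` — 1690 nM
compound 3, `S=C(NCc1cccnc1)SCCc1nnc(-c2ccccc2)o1` — 580 nM

All three were tested in a functional assay on SK-BR-3 cells (Homo sapiens) for cytotoxicity, read by resazurin assay, with a stated time of 72 h; a higher number here means a weaker inhibitor, a lower number a stronger inhibitor. Compound 3 has the lowest number of the three. Its value sits within the usual scatter of the value of compound 1, so no real difference between the two can be claimed; the value of compound 2 lies beyond that scatter, so compound 3 does separate from compound 2. Within the data shown here, no pair of these three differs in only one place, so none of the gaps between them can be tied to a single structural change.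

Compound 4, `Cc1cc(-c2nnc(CCSC(=S)NCc3cccnc3)o2)no1`, has not yet been measured in this assay. It differs from compound 3 in one place: 5-methyl-1,2-oxazol-3-yl in place of phenyl on an aromatic carbon. The group that leaves and the group that enters are of the same heavy-atom count, and the spot is the same aromatic carbon of the five-membered ring with 2 nitrogen and 1 oxygen.

Nothing among the three measured compounds shows what this particular exchange does, so the step of a 1.2-fold higher number from compound 3 to compound 4 (0.08 log units; within the scatter) is expected to stay within the scatter, in no clear direction. On that basis compound 4 is estimated at 700 nM, with a range from 250 nM to 2000 nM.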

Compound 4, half-maximal inhibitory concentration: 1730 nM
For compound 4 the middle estimate is 2.5-fold (0.39 log units) below the measured one; the range from low to high includes it.
By their numbers in this assay, from the lowest: compounds 3, 1, 2 and 4 (each within the scatter of the next, the first and the last beyond it).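

In this assay, among these compounds, the exchange of phenyl for 5-methyl-1,2-oxazol-3-yl is the first change in this set that can be read on its own, and it gives a 3.0-fold higher number from compound 3 to compound 4 (0.47 log units; beyond the scatter). At this aromatic carbon of the five-membered ring with 2 nitrogen and 1 oxygen, then, one aromatic group cannot simply be traded for another with the same heavy-atom count without the number moving beyond the scatter. The two groups differ in ring size, in their hetero atoms and in their hydrogen-bond acceptors, and nothing measured here separates these differences or gives a reason for the step.

From the compounds shown here alone, whether an unsubstituted 1,2-oxazol-3-yl, a pyridyl ring or a cyclohexyl group at this carbon would give a number closer to that of compound 3 or to that of compound 4 remains open, and such groups would help show whether the methyl, the hetero atoms or the smaller ring goes with the change. Going by these compounds, this is also a single pair, so it remains open whether the same exchange would have a similar effect with a different chain on the dithiocarbamate sulfur.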